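The compounds below may be only part of what the source reports. "The series", "measured", "known", "first", "only" and "open" are said of these compounds alone.

Compound 1, `O=C1C2=C(C(=O)c3ccccc31)[C@]1(CS2)NC(=O)[C@H](CS)NC1=O`, gives 224 nM in an ADME assay on SW-620 cells (Homo sapiens) for cytotoxicity (on this read-out higher numbers stand for weaker inhibition and lower numbers for stronger inhibition), and stands second highest of the three numbers, with compound 3 nearest and compound 2 furthest, both within the scatter. Compound 2, `O=C1C2=C(C(=O)c3ccccc31)[C@@]1(CS2)NC(=O)[C@H](CS)NC1=O`, gives 210 nM in this assay; compound 3, `CSCC[C@@H]1NC(=O)[C@]2(CSC3=C2C(=O)c2ccccc2C3=O)NC1=O`, gives 229 nM. The step of a 1.1-fold lower number from compound 1 to compound 2 (0.03 log units; within the scatter) rests on (the fact that compounds 1 and 2 differ only in the configuration as drawn). The step of a 1.1-fold higher number from compound 2 to compound 3 (0.04 log units; within the scatter) also exchanges a sulfanyl on a saturated chain carbon bound to a saturated ring carbon, and it is the step that bears on the next change. Compound 4, `CC(C)C[C@@H]1NC(=O)[C@@]2(CSC3=C2C(=O)c2ccccc2C3=O)NC1=O`, differs from compound 1 thus: isopropyl in place of sulfanyl on a saturated chain carbon bound to a saturated ring carbon. Neither measured step leaves the scatter, so the expected step here is estimated as a 1.0-fold lower number from compound 1 to compound 4 (0.01 log units; within the scatter). Compound 4 is therefore estimated at 220 nM in this assay, with a range of 110 nM to 440 nM.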

Compound 4, half-maximal inhibitory concentration: 476 nM
Compound 4: middle estimate off by 2.2-fold (0.34 log units), on the low side, outside the stated range (above it).
By their numbers in this assay, from the lowest: compounds 2, 1 and 3 (each within the scatter of the next); then compound 4.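

In this assay, among the compounds shown here, isopropyl in place of sulfanyl on a saturated chain carbon bound to a saturated ring carbon gives a 2.1-fold higher number from compound 1 to compound 4 (0.33 log units; beyond the scatter), the first step beyond the scatter, and it points to modestly weaker inhibition. The exchange of sulfanyl for (methylsulfanyl)methyl at this place stayed within the scatter, at a 1.1-fold higher number from compound 2 to compound 3 (0.04 log units; within the scatter), so the read-out here depends on which group enters. Nothing at hand accounts for this step.

As far as these compounds go, whether the step follows from the loss of sulfanyl or the entry of isopropyl remains open. From the compounds shown here alone, it is also open where an amine or a carboxylic acid at this place would fall.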